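The source may hold more compounds than are shown below. What is called first, only, known or untested is meant among the compounds shown, and "the series" means these compounds.

Working notes on the series. Compound 3 `Cc1nc(-c2ccc(N3C(=O)C(O)=C(C(=O)C(C)(C)C)C3c3ccccc3OCCO)cc2)no1` has in a physicochemical assay for solubility, in phosphate buffer, at pH 6.8 (a lower number here means a less soluble compound, a higher number a more soluble compound), no number but a limit: compound 3 gives > 50000 nM, which is a limit of the measurement. Compound 1 `O=C(C1=C(O)C(=O)N(c2ccc(-c3ccon3)cc2)C1C1CCCCC1)c1ccc(CO)cc1` in this assay likewise reaches only a limit, at > 50000 nM. Compound 2 `COc1ccc(C(=O)C2=C(O)C(=O)N(c3ccc(-c4ccon4)cc3)C2c2ccccc2OCCO)cc1` in this assay also stops at a limit, > 50000 nM. Compound 3 therefore stands where every measured compound of the series stands, namely at the limit of > 50000 nM in this assay, at which 3 of the 3 values shown sit; no measured value falls below that point, and no order among the three compounds can be drawn from it.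

Compound 4 `CC(C)(C)C(=O)C1=C(O)C(=O)N(c2ccc(-c3cccs3)cc2)C1c1ccccc1OCCO` has not yet been measured in this assay. It differs from compound 3 in one place: thiophen-2-yl in place of 5-methyl-1,2,4-oxadiazol-3-yl on an aromatic carbon. Among the compounds with values here, no step between two measured compounds exists, so the size of such a change cannot be read from measured data here. The expected step is an at least 1.6-fold lower number from compound 3 to compound 4 (0.22 log units; that floor lies within the scatter), a moderate move downward, though the value may again only reach the limit. For compound 4 the estimate in this assay is 30000 nM, expected to fall between 10000 nM and 50000 nM.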

Compound 4, solubility: 38600 nM
For compound 4 the middle estimate is 1.3-fold (0.11 log units) below the measured one; the range from low to high includes it.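

In this assay, within the data shown here, compound 4 gives 38600 nM, the only value of the series that is a number and not a limit: the limit of > 50000 nM in this assay, at which 3 of the 4 values shown sit. Thiophen-2-yl in place of 5-methyl-1,2,4-oxadiazol-3-yl, on an aromatic carbon of a six-membered aromatic ring of carbon only, para to a large group, gives an at least 1.2-fold lower number from compound 3 to compound 4 (0.11 log units; that floor lies within the scatter). Among these compounds, the earlier compounds showed no number at all, whereas this exchange shows that a change at this one place can bring the read-out off the limit; the start of the step is itself a limit, so only a floor is known, and the true size of the step stays open.

The compounds shown leave open where the number would lie with an amine or a carboxylic acid on this aromatic carbon, in place of either five-membered aromatic ring. On these data alone, it also remains open whether thiophen-2-yl gives a number on the core of compound 1 or compound 2, as the steps involving those two compounds cannot be read.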